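This account rests on a few compounds, and the source may have more. Where it says the series, first, only, none or still open, it means among the compounds named here.

Working notes on the series. In a functional assay on LOX IMVI cells (Homo sapiens) for inhibition, read by sulforhodamine B assay, with a stated time of 48 h (a higher number here means a weaker inhibitor of growth, a lower number a stronger inhibitor of growth), compound 1 (`COc1cc2nc(-c3ccc(Cl)cc3)cc(OCCCN3CCC(O)CC3)c2cc1OC`) gives 589 nM and compound 2 (`COc1cc2nc(-c3ccc(C(F)(F)F)cc3)cc(OCCCN3CCCCC3)c2cc1OC`) gives 355 nM. For the measured compounds named here, these are the only two numbers so far, and they lie within the usual scatter of each other, so compound 2 stands level with compound 1 and no order can be read from them.

Compound 3 (`COc1cc2nc(-c3ccc(C(F)(F)F)cc3)cc(OCCCN3CCC(O)CC3)c2cc1OC`) follows from compound 2 by one change, hydroxy in place of hydrogen on a saturated ring carbon, three ring bonds from the ring nitrogen, so that piperidin-1-yl becomes 4-hydroxypiperidin-1-yl: hydroxy in place of hydrogen on a saturated ring carbon. Going by the values given here, no measured pair differs by this change alone, so its size is not known directly. Compound 1 already carries the 4-hydroxypiperidin-1-yl group and gives 589 nM, a value within the scatter of compound 2, which points to no large move. The expected change in this assay is small and within the scatter, with a slight lean toward a higher number, estimated as a 1.3-fold higher number from compound 2 to compound 3 (0.10 log units; within the scatter). For compound 3 the expected value is 450 nM, with an estimated range of 200 nM to 1000 nM.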

Compound 3, concentration for total growth inhibition: 447 nM
Estimate against measurement, compound 3: 1.0-fold (0.00 log units) above; the measured number falls inside the stated range.
By their numbers in this assay, from the lowest: compounds 2, 3 and 1 (each within the scatter of the next).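

With the trifluoromethyl group held fixed, the change from piperidin-1-yl to 4-hydroxypiperidin-1-yl can now be read directly in this assay as a 1.3-fold higher number from compound 2 to compound 3 (0.10 log units; within the scatter), so the added hydroxy, three ring bonds from the ring nitrogen, gives no step beyond the scatter. For the compounds shown here, with 4-hydroxypiperidin-1-yl held fixed, the first direct reading of trifluoromethyl in place of chloro on an aromatic carbon is a 1.3-fold lower number from compound 1 to compound 3 (0.12 log units; within the scatter), so this change also stays within the scatter. No evidence in hand bears on either step.

Hydroxy is the only replacement for hydrogen at this ring carbon among the compounds shown, leaving open whether an amine, a carboxylic acid or a methoxy group there would move the number beyond the scatter. Also open, as far as these compounds go, are the effects of a longer chain carrying the piperidin-1-yl group and of a nitrile in place of trifluoromethyl on the aromatic carbon.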